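The compounds below may be only part of what the source reports. "The series", "measured", "known", "first", "only" and "open" are said of these compounds alone.

Measured in a functional assay for inhibition, with Homo sapiens as the target; a lower number here means tighter binding, a higher number weaker binding:
Compound 1 `CC(C)(Oc1ccccc1)C1OCC(C/C=C\CCC(=O)O)C(c2cccnc2)O1`: 75.9 nM
Compound 2 `CC(C)(Oc1ccc(F)cc1)C1OCC(C/C=C\CCC(=O)O)C(c2cccnc2)O1`: 120 nM

Compound 2 stands within the scatter of compound 1, so the two cannot be ranked. The change to compound 3 `Cc1ccc(OC(C)(C)C2OCC(C/C=C\CCC(=O)O)C(c3cccnc3)O2)cc1` is methyl in place of fluoro on an aromatic carbon, para to a large group. Within the data shown here, one measured step bears on it, a 1.6-fold higher number from compound 1 to compound 2 (0.20 log units; within the scatter), with fluoro in place of hydrogen on an aromatic carbon, and that step lies within the scatter. No step beyond the scatter is therefore expected in this assay. The expected step is a 1.2-fold lower number from compound 2 to compound 3 (0.08 log units; within the scatter). For compound 3 the estimated value is 100 nM, with an expected range from 45 nM to 220 nM.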

Compound 3, dissociation constant: 631 nM
For compound 3 the middle estimate is 6.3-fold (0.80 log units) below the measured one; the measured number lies above the stated range.
By their numbers in this assay, from the lowest: compounds 1 and 2 (each within the scatter of the next); then compound 3.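

In this assay the position para to a large group responds to what it carries: methyl in place of fluoro gives a 5.3-fold higher number from compound 2 to compound 3 (0.72 log units; beyond the scatter) and methyl in place of hydrogen gives an 8.3-fold higher number from compound 1 to compound 3 (0.92 log units; beyond the scatter) while fluoro and hydrogen there could not be ranked. Of these three groups, only methyl moves the number beyond the scatter, and it moves it upward. Nothing available explains this result. As far as these compounds go, whether a chlorine or a methoxy group at this position would behave like fluoro or like methyl remains open.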